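The source may hold more compounds than are shown below. What is called first, only, known or untested is meant among the compounds shown, and "the series" means these compounds.

Among the measured compounds shown here, in a functional assay on HEK293 cells for agonist activity at D(4) dopamine receptor (Homo sapiens), read by FLIPR (a lower number here means a smaller maximal response, a higher number a larger maximal response), compound 2 `Cc1ccc(Cl)cc1NC(=O)CN1CCC(c2cccc[n+]2[O-])CC1` gives 58%, the lower of the two numbers so far, with compound 1 `CCc1cccc(NC(=O)CN2CCC(c3cccc[n+]3[O-])CC2)c1` nearest at 62%; the step of a number 4 percentage points lower from compound 1 to compound 2 (within the scatter) lies within the scatter. Compound 3 `Cc1cccc(C)c1NC(=O)CN1CCC(c2cccc[n+]2[O-])CC1` differs from compound 2 by 2,6-dimethylphenyl in place of 5-chloro-2-methylphenyl on an amide-type nitrogen. For the measured compounds named here, the only measured step that bears on this, the aryl exchange from compound 1 to compound 2, stayed within the scatter, so no step beyond the scatter is expected here either, an estimated a number 2 percentage points higher from compound 2 to compound 3 (within the scatter). Compound 3 is therefore estimated at 60%, with a range of 45% to 75%.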

Compound 3, largest response reached (reported as efficacy), in percent of the reference or control that the assay uses: 68%
Estimate against measurement, compound 3: 8 percentage points below, within the range that was stated.
By their numbers in this assay, from the lowest: compounds 2, 1 and 3 (each within the scatter of the next).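

In this assay, 2,6-dimethylphenyl on the amide-type nitrogen gives a number 10 percentage points higher from compound 2 to compound 3 (within the scatter) and a number 6 percentage points higher from compound 1 to compound 3 (within the scatter). This position therefore accepts three different aryl groups, now including one with two methyl groups and no chlorine, with no step beyond the scatter among compounds 1, 2 and 3. Nothing available explains these numbers. Going by these compounds, it remains open whether a more different group on this aryl ring, such as a carboxylic acid or an amine, would give a step beyond the scatter.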